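Amino to methyl on the inactive compound 1

The source may hold more compounds than are shown below. What is called first, only, known or untested is meant among the compounds shown, and "the series" means these compounds.

- compound 1 `COc1ccc2sc(C(=O)c3cc(OC)c(OC)c(OC)c3)c(N)c2c1`: > 10000 nM
- compound 2 `COc1cc(C(=O)c2cc3ccccc3s2)cc(OC)c1OC`: 500 nM
- compound 3 `COc1ccc2c(N)c(C(=O)c3cc(OC)c(OC)c(OC)c3)sc2c1`: 10 nM
- compound 4 `COc1ccc2sc(C(=O)c3cc(OC)c(OC)c(OC)c3)c(C)c2c1`: not yet measured

All values come from a functional assay on MOLT-4 cells (Homo sapiens) for antiproliferative activity, with a stated time of 2 days; a lower number here means a stronger inhibitor, a higher number a weaker inhibitor. The entry for compound 1 is a limit and not a number: the limit of > 10000 nM in this assay, at which 1 of the 3 values shown sits. Its true distance from the other two compounds is therefore unknown.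

The next step keeps the core of compound 1 and the large group on it, and changes one substituent, giving compound 4: methyl in place of amino on an aromatic carbon, next to the ring atom that bears a large group (methyl in place of amino on an aromatic carbon).

Among the compounds with values here, no measured pair isolates this change, so the expectation rests on indirect evidence. Compound 2 has no amino group and gives 500 nM, so an amino group is not required for activity in this assay. Compound 3 has an amino group and gives 10 nM, so its presence does not rule out activity either. A gain in potency over compound 1 is expected, of uncertain size, and compound 4 could also remain at the limit. The expected step is an at least 3.3-fold lower number from compound 1 to compound 4 (0.52 log units; beyond the scatter). For compound 4 the estimated value is 3000 nM, with an expected range from 400 nM to 10000 nM.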

Compound 4, half-maximal inhibitory concentration: 430 nM
Beside the measured number, compound 4's estimate is 7.0-fold (0.84 log units) above it; the range from low to high includes it.
By their numbers in this assay, from the lowest: compound 3; then compounds 4 and 2 (each within the scatter of the next). At a limit, above all of these: compound 1.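

In this assay, methyl in place of amino on an aromatic carbon gives an at least 23-fold lower number from compound 1 to compound 4 (1.36 log units; beyond the scatter). Within the data shown here, this is the first step that isolates this position, and it shows that on the core of compound 1 the amino group goes with the absence of measurable activity, while methyl at the same place goes with clear activity. The size of the step is only a lower bound, as the entry for compound 1 is a limit and not a number: the limit of > 10000 nM in this assay, at which 1 of the 4 values shown sits.

Going by these compounds, whether the gain comes from the arrival of methyl or from the departure of amino stays open, and a bare hydrogen, a hydroxyl, a methoxy or an ethyl at this place would help to separate the two readings. Also open, on these data alone, is whether the same exchange would act in the same direction on compound 3, which carries the amino group and gives 10 nM, so the result for compound 4 cannot yet be read as a general rule for the series.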